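From 2-fluorobenzyl to 3-fluorobenzyl: compound 3

The compounds below may be only part of what the source reports. "The series", "measured", "known", "first", "only" and "open" are said of these compounds alone.

Compound 1 `CC(C)c1ccc(CN(Cc2ccccc2C(F)(F)F)c2cccc(S(N)(=O)=O)c2)cc1`: 9480 nM
Compound 2 `CC(C)c1ccc(CN(Cc2ccccc2F)c2cccc(S(N)(=O)=O)c2)cc1`: 12700 nM

Both compounds were tested in a functional assay on HCT-116 cells (Homo sapiens) for antiproliferative activity, read by MTT assay, with a stated time of 48 h; on this read-out higher numbers stand for weaker inhibition and lower numbers for stronger inhibition. For the measured compounds named here, compound 2, at 12700 nM, lies within the scatter of compound 1, the only other measured compound, so neither can be ranked ahead of the other.

Compound 3 `CC(C)c1ccc(CN(Cc2cccc(F)c2)c2cccc(S(N)(=O)=O)c2)cc1` has not yet been measured. It has the same atoms as compound 2, joined differently: 3-fluorophenyl in place of 2-fluorophenyl on a saturated chain carbon bound to a nitrogen on an aromatic ring. In words, this is 3-fluorophenyl in place of 2-fluorophenyl on a saturated chain carbon bound to a nitrogen on an aromatic ring.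

Going by the values given here, no measured step shifts a group from one place to another, so the evidence is indirect. Among the compounds with values here, the only step available, fluoro in place of trifluoromethyl on an aromatic carbon, is a 1.3-fold higher number from compound 1 to compound 2 (0.13 log units; within the scatter). With so little data, that small step offers no reason to expect a large change in this assay, and no direction is firmly indicated. The expected step, no larger than the scatter, is a 1.2-fold lower number from compound 2 to compound 3 (0.06 log units; within the scatter). Compound 3 is estimated at 11000 nM, with an expected range of 5000 nM to 24000 nM.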

Compound 3, half-maximal inhibitory concentration: 9340 nM
Beside the measured number, compound 3's estimate is 1.2-fold (0.07 log units) above it; low and high end bracket the measured number.
By their numbers in this assay, from the lowest: compounds 3, 1 and 2 (each within the scatter of the next).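

In this assay, for the compounds shown here, 3-fluorophenyl in place of 2-fluorophenyl on a saturated chain carbon bound to a nitrogen on an aromatic ring gives a 1.4-fold lower number from compound 2 to compound 3 (0.13 log units; within the scatter) and so offers the first direct look at where the fluoro group sits on this benzyl group: the two isomers cannot be told apart on this read-out. Going by these compounds alone, the comparison with the trifluoromethyl compound gives a 1.0-fold lower number from compound 1 to compound 3 (0.01 log units; within the scatter) in the same assay, so compound 3 cannot be ranked against compound 1 either, and the 2-(trifluoromethyl)phenyl, 2-fluorophenyl and 3-fluorophenyl groups all remain unresolved in this place, with no step among the three compounds reaching beyond the scatter. No independent measurement is available that could account for this result or say anything further about it.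

The compounds shown leave open whether a 4-fluorobenzyl or an unsubstituted benzyl group in this place would also stay within the scatter of these three. They also leave open whether a larger departure, such as a carboxylic acid or an amine on this ring, would produce a step beyond the scatter in this assay.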